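Cytotoxicity of Cyclic Sulfonate Ethers in HEL Cells

The source may hold more compounds than are shown below. What is called first, only, known or untested is meant among the compounds shown, and "the series" means these compounds.

Compound 1 `CCC1(Cc2ccccc2)OS(=O)(=O)C=C1OCc1ccc(OC)cc1` in an ADME assay on HEL cells (Homo sapiens) for cytotoxicity, with a stated time of 3 days (on this read-out lower numbers stand for higher toxicity in this test and higher numbers for lower toxicity in this test), gives a limit of >= 200000 nM.
Compound 2 `CCC1(Cc2ccccc2)OS(=O)(=O)C=C1OCCCc1ccccc1` gives a limit of >= 20000 nM.
Compound 3 `CCC1(Cc2ccccc2)OS(=O)(=O)C=C1OCCCCc1ccccc1` gives a limit of >= 20000 nM.

All three values are limits of the assay rather than numbers, so compound 3 cannot be placed above or below its neighbours on the numbers shown; it sits, together with compound 2, at the limit of >= 20000 nM in this assay, at which 2 of the 3 values shown sit, while compound 1 sits at the limit of >= 200000 nM in this assay, at which 1 of the 3 values shown sits. The step that the two limits leave unreadable from compound 1 to compound 2 and the step that the two limits leave unreadable from compound 1 to compound 3 are left unreadable by the two limits, and the same holds for a step that the two limits leave unreadable from compound 2 to compound 3.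

Compound 4 `CCC1(Cc2ccccc2)OS(=O)(=O)C=C1OCC=C(C)C` differs from compound 3 in that (2-methylprop-1-en-1-yl in place of 3-phenylpropyl on a saturated chain carbon bound to an oxygen on an unsaturated carbon). Within the data shown here, none of the measured steps reports a readable size, so no direction can be expected beyond the scatter; what the data do show is that each of the three variations of the ether side chain stayed at a limit in this assay. Compound 4 is therefore expected to give a limit once more, with a step that the limit leaves unreadable from compound 3 to compound 4 estimated at no readable size. For compound 4 the estimate is 50000 nM, within 20000 nM to 200000 nM.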

Compound 4, minimum cytotoxic concentration: 400000 nM
Estimate against measurement, compound 4: 8.0-fold (0.90 log units) below; measured number above the stated range.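

Compound 4 gives a number, but compound 1, compound 2 and compound 3 each stand at a limit of the assay, so none of their steps to compound 4 can be read. The compounds shown leave open whether any change of the ether side chain shifts the read-out in this assay at all, and in which direction.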